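Chloro next to the ring nitrogen in the biaryl member

The source may report more compounds than this note shows. Statements on the series, on what has been measured and on what is new or still open speak of the compounds shown alone.

Compound 3 `c1ccc(-c2cncc(O[C@@H]3CCNC3)c2)cc1` gives 1820 nM in an assay on a protein complex for binding affinity to Neuronal acetylcholine receptor; alpha4/beta2 (Rattus norvegicus) (a higher number here means a weaker inhibitor, a lower number a stronger inhibitor), the highest of the three numbers at hand; compound 2 `Cc1cc(O[C@@H]2CCNC2)cnc1Cl` gives 64 nM and compound 1 `C#Cc1cc(O[C@@H]2CCNC2)cnc1Cl` gives 46 nM, both well beyond the scatter below compound 3. Compound 4 `Clc1ncc(O[C@@H]2CCNC2)cc1-c1ccccc1` carries chloro in place of hydrogen on an aromatic carbon, next to the ring nitrogen, ortho to the phenyl group and para to the (pyrrolidin-3-yl)oxy group. Within the data shown here, no measured step isolates this change; the only step on record, a 1.4-fold higher number from compound 1 to compound 2 (0.14 log units; within the scatter), concerns another position and is within the scatter. Compounds 1 and 2 both carry a chloro and sit far lower than compound 3, yet they differ from it in two places, so direction stays uncertain. Compound 4 is expected to give 600 nM in this assay, between 150 nM and 2500 nM, a step of a 3.0-fold lower number from compound 3 to compound 4 (0.48 log units; beyond the scatter) that is estimated rather than measured.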

Compound 4, half-maximal inhibitory concentration: 75 nM
Beside the measured number, compound 4's estimate is 8.0-fold (0.90 log units) above it; the whole stated range lies above it.
By their numbers in this assay, from the lowest: compounds 1, 2 and 4 (each within the scatter of the next); then compound 3.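

In this assay, chloro in place of hydrogen on the aromatic carbon next to the ring nitrogen gives a 24-fold lower number from compound 3 to compound 4 (1.39 log units; beyond the scatter), so this single change carries a large step in the phenyl member. With chloro present, the other aromatic substituent separates nothing here: phenyl in place of methyl gives a 1.2-fold higher number from compound 2 to compound 4 (0.07 log units; within the scatter), and phenyl in place of ethynyl gives a 1.6-fold higher number from compound 1 to compound 4 (0.21 log units; within the scatter). No supporting data bear on the origin of the chloro step.

From the compounds shown here alone, whether fluoro, bromo or an amine at this position would give a similar step remains open. Also open, going by these compounds, is whether the chloro step holds with methyl or ethynyl in place of phenyl.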